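Swapping fluoro for methyl on the cyclopropyl ring

The source may report more compounds than this note shows. Statements on the series, on what has been measured and on what is new or still open speak of the compounds shown alone.

Among the compounds with values here, compound 2 `O=C([C@@H]1C[C@H]1F)N1CC2CC(C1)N2` gives the lowest number of the two measured so far in an assay on CHO cells for displacement of a labelled ligand from Neuronal acetylcholine receptor; alpha3/alpha6/beta2/beta3 (Homo sapiens), read by scintillation counting (on this read-out higher numbers stand for weaker inhibition and lower numbers for stronger inhibition), at 43 nM. Compound 1 `CC(=O)N1CC2CC(C1)N2`, the simple acetyl analogue, gives 610 nM in this assay, so the step of a 14-fold lower number from compound 1 to compound 2 (1.15 log units; beyond the scatter) is the only one measured, and it concerns the replacement of the whole methyl by 2-fluorocyclopropyl on the carbonyl carbon. Compound 3 `C[C@@H]1C[C@H]1C(=O)N1CC2CC(C1)N2` keeps the cyclopropyl ring and differs from compound 2 only in one place: methyl in place of fluoro on a saturated ring carbon, that is, 2-fluorocyclopropyl becomes 2-methylcyclopropyl. Within the data shown here, no measured step tells how fluoro and methyl compare on this ring, so the large gain from compound 1 to compound 2 cannot be read as a guide for this smaller change in either direction. The expectation for compound 3 is therefore a step of a 1.9-fold higher number from compound 2 to compound 3 (0.27 log units; within the scatter) that stays near the scatter, and compound 3 is estimated at 80 nM in this assay, within a range of 25 nM to 260 nM.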

Compound 3, inhibition constant: 14 nM
For compound 3 the middle estimate is 5.7-fold (0.76 log units) above the measured one, outside the stated range (below it).
By their numbers in this assay, from the lowest: compound 3; then compound 2; then compound 1.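

On the cyclopropyl ring, fluoro is not needed for strong binding: in this assay, methyl in place of fluoro on this saturated ring carbon gives a 3.1-fold lower number from compound 2 to compound 3 (0.49 log units; beyond the scatter) and so improves on the fluorinated compound. The large gain over the acetyl compound therefore also appears with a carbon group on the ring, seen as a 44-fold lower number from compound 1 to compound 3 (1.64 log units; beyond the scatter) when 2-methylcyclopropyl takes the place of methyl on the carbonyl carbon. Nothing available explains why methyl gives the lower number here.

Fluoro and methyl are the only groups shown on this ring carbon, so it remains open whether a longer chain such as ethyl, or a hydroxyl or an amine, would lower the number further or raise it. Going by these compounds, it also remains open how much of the gain comes from the ring itself, which an unsubstituted cyclopropyl or an open isopropyl group would help to show.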